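This account rests on a few compounds, and the source may have more. Where it says the series, first, only, none or still open, it means among the compounds named here.

Measured compounds:
compound 1 `COCCN/C(=C1/N=CN(CCOC)C1=O)c1cc2cccnc2[nH]1`, in an assay on isolated protein for inhibition of Calpain-1 catalytic subunit (Homo sapiens), read by fluorescence, with a stated time of 60 min (a lower number here means a stronger inhibitor, a higher number a weaker inhibitor), compound 1 gives 380 nM
compound 2 `COCCN/C(=C1/N=CN(CCOC)C1=O)c1cc2ccccc2[nH]1`, compound 2 gives 460 nM
compound 3 `CC(C)N/C(=C1/N=CN(C(C)C)C1=O)c1cc2ccccc2[nH]1`, compound 3 gives only a limit in this assay: > 1000 nM

Compound 2 stands alongside compound 1; the two values differ by less than the usual scatter of repeated measurements and so cannot be ordered. Compound 3 sits at the limit of this assay, described by the limit of > 1000 nM in this assay, at which 1 of the 3 values shown sits, and gives no number to compare.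

The next compound, compound 4 `COCCN/C(=C1/N=C(C)N(CCOC)C1=O)c1cc2ccccc2[nH]1`, has not been measured. It differs from compound 2 in one place:

methyl in place of hydrogen on a carbon with a double bond to nitrogen

Among the measured compounds shown here, no measured pair shows the effect of such a change, so no step size is available from the data. The 2-methoxyethyl groups shared by compound 1 and compound 2 are kept. In this assay a small step is expected, if any, toward a somewhat higher number, within or close to the scatter. The estimate for compound 4 in this assay is 650 nM, with a range from 250 nM to 1700 nM, which corresponds to an expected step of a 1.4-fold higher number from compound 2 to compound 4 (0.15 log units; within the scatter).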

Compound 4, half-maximal inhibitory concentration: 20 nM
Compound 4: middle estimate off by 33-fold (1.51 log units), on the high side; the whole stated range lies above it.
By their numbers in this assay, from the lowest: compound 4; then compounds 1 and 2 (each within the scatter of the next). At a limit, above all of these: compound 3.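

In this assay, the carbon with a double bond to nitrogen, between two ring nitrogen atoms, proves to be a sensitive position in this series. Methyl in place of hydrogen there gives a 23-fold lower number from compound 2 to compound 4 (1.36 log units; beyond the scatter) and is the first single-place step available, showing that one added carbon at this position can move the number well beyond the scatter. Nothing measured here accounts for the size of this step.

As far as these compounds go, whether the effect is specific to methyl remains open: an ethyl group, a cyclopropyl group or an amine at the same position could show how far the change can be taken. From the compounds shown here alone, it is also open whether methyl gives a step of similar size on the core of compound 1 or with other groups in place of the 2-methoxyethyl groups.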